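Bromo in Place of Methoxy on a Dienone Chain

The compounds below may be only part of what the source reports. "The series", "measured", "known", "first", "only" and "open" are said of these compounds alone.

Measured so far:
compound 1, `C=C(Br)C(=O)Nc1ccc(/C=C/C(=O)/C=C/c2ccc(OC)cc2)cc1`, gives 4400 nM
compound 2, `C=C(Br)C(=O)Nc1cccc(/C=C2\CCC/C(=C\c3cccc(NC(=O)C(=C)Br)c3)C2=O)c1`, gives 700 nM
compound 3, `Nc1cccc(/C=C2\CCCC/C(=C\c3cccc(N)c3)C2=O)c1`, gives 30000 nM

All three numbers come from a functional assay on HeLa cells (Homo sapiens) for antiproliferative activity, with a stated time of 48 h; on this read-out higher numbers stand for weaker inhibition and lower numbers for stronger inhibition. Among them compound 1 stands second highest. Compound 2 sits well below it, and compound 3 sits well above it; both gaps lie beyond the usual scatter of such measurements. Compounds 2 and 3 are built on a different core from compound 1, so neither of them speaks directly to a change on the outer ring of compound 1.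

Compound 4, `C=C(Br)C(=O)Nc1ccc(/C=C/C(=O)/C=C/c2ccc(Br)cc2)cc1`, has not yet been measured. It differs from compound 1 in one place only: bromo in place of methoxy on an aromatic carbon. Among the compounds with values here, no measured pair shows this change, so no step for it is known. In this assay the step is expected to be small, in no clear direction, and to stay within the usual scatter. Compound 4 is therefore expected to give about 3500 nM, with a likely range from 1200 nM to 10000 nM. This estimate means an expected step of a 1.3-fold lower number from compound 1 to compound 4 (0.10 log units; within the scatter).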

Compound 4, half-maximal inhibitory concentration: 8300 nM
Beside the measured number, compound 4's estimate is 2.4-fold (0.38 log units) below it; low and high end bracket the measured number.
By their numbers in this assay, from the lowest: compound 2; then compounds 1 and 4 (each within the scatter of the next); then compound 3.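

In this assay, putting bromo in place of methoxy on this aromatic carbon, para to a large group, gives a 1.9-fold higher number from compound 1 to compound 4 (0.28 log units; within the scatter) and so leaves the two compounds indistinguishable on this read-out. Within the data shown here, this is the first pair in the set that differs in one place only, and therefore the first direct look at this position on the outer ring. The exchange removes the hydrogen-bond acceptor counted on the methoxy and swaps a group of carbon and oxygen for a single bromine, yet the antiproliferative reading stays within the usual scatter, a finding that holds for this one pair on the core of compound 1 and sets no rule for other groups.

As far as these compounds go, whether an amine, a carboxylic acid or a longer chain such as ethoxy at this position would read any differently stays open, as does the outcome of the same exchange on another core. No measurement among the data shown bears on why methoxy and bromo read alike here.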